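From 4-fluorophenoxy to 4-chlorophenyl on a shared core

The source may hold more compounds than are shown below. What is called first, only, known or untested is meant among the compounds shown, and "the series" means these compounds.

Of the compounds shown here, three with one shared core have been tested in an ADME assay on cells (Peritoneal macrophage cell, Mus musculus) for cytotoxicity; a higher number here means a weaker inhibitor, a lower number a stronger inhibitor. Compound 1 `O=C(Cn1cnc([N+](=O)[O-])n1)Nc1ccc(Oc2ccccc2)cc1` gives 89000 nM, compound 2 `O=C(Cn1cnc([N+](=O)[O-])n1)Nc1ccc(Oc2ccc(Cl)cc2)cc1` gives 80000 nM, and compound 3 `O=C(Cn1cnc([N+](=O)[O-])n1)Nc1ccc(Oc2ccc(F)cc2)cc1` gives 84000 nM. Compound 3 therefore cannot be told apart from the other two, since all three numbers lie within the usual scatter of one another.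

The next compound, compound 4 `O=C(Cn1cnc([N+](=O)[O-])n1)Nc1ccc(-c2ccc(Cl)cc2)cc1`, carries 4-chlorophenyl in place of 4-fluorophenoxy on an aromatic carbon. The measured steps bear on only part of this change. Adding a halogen gave a 1.1-fold lower number from compound 1 to compound 2 (0.05 log units; within the scatter) and a 1.1-fold lower number from compound 1 to compound 3 (0.03 log units; within the scatter), while exchanging one halogen for the other gave a 1.1-fold higher number from compound 2 to compound 3 (0.02 log units; within the scatter). Each of these steps is within the scatter, so moving from fluoro to chloro is not expected to matter much. For the measured compounds named here, no measured compound tests the loss of the oxygen in 4-fluorophenoxy, and that part of the change remains unknown. No step beyond the scatter is expected, and the estimated move is a 1.2-fold lower number from compound 3 to compound 4 (0.08 log units; within the scatter). For compound 4 the expected value is 70000 nM, with an estimated range from 30000 nM to 150000 nM.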

Compound 4, half-maximal inhibitory concentration: > 84000 nM
Compound 4 gave a limit, no number (the forecaster's own chance of this, stated with the estimate: 15%); at least 1.2-fold (0.07 log units) between middle value and limit.
By their numbers in this assay, from the lowest: compounds 2, 3 and 1 (each within the scatter of the next).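

In this assay compound 4 gives > 84000 nM, which is a limit and not a number. The change from 4-fluorophenoxy to 4-chlorophenyl gives a number no lower from compound 3 to compound 4 (the limit leaves the size open). Compound 2 and compound 4 differ only in the oxygen link. Both carry the same chlorine-bearing ring. Going by these compounds, the change from 4-chlorophenoxy to 4-chlorophenyl gives an at least 1.0-fold higher number from compound 2 to compound 4 (0.02 log units; that floor lies within the scatter), so it shows no lower number, while the true size of the step stays open. The step to compound 4 from compound 1 cannot be read, and the only value that is not a plain number is this one: the limit of > 84000 nM in this assay, at which 1 of the 4 values shown sits.

The compounds shown leave open how far the value of compound 4 lies from those of the other three, and whether any change at this position can move the number beyond the scatter. An amine or a carboxylic acid in place of the 4-chlorophenyl on the shared core would test this position with a group quite unlike the aromatic rings seen so far.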